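Adding an Ethoxycarbonyl Group to a Thiazole Inhibitor

The source may hold more compounds than are shown below. What is called first, only, known or untested is meant among the compounds shown, and "the series" means these compounds.

Measured compounds:
- Compound 1, `Cc1csc(NC(=O)Cn2cc(-c3ccncc3)nn2)n1`: 100 nM
- Compound 2, `Cc1csc(NC(=O)Cn2cc(-c3cccs3)nn2)n1`: 40 nM

Among the compounds with values here, in a functional assay on BMDM cells (Mus musculus, strain C57BL/6) for inhibition, with a stated time of 2 days (a lower number here means a stronger inhibitor, a higher number a weaker inhibitor), compound 1 gives 100 nM, the highest of the two numbers measured so far. The nearest compound is compound 2, which shows a 2.5-fold lower number from compound 1 to compound 2 (0.40 log units; beyond the scatter).

The unmeasured compound 3, `CCOC(=O)c1sc(NC(=O)Cn2cc(-c3ccncc3)nn2)nc1C`, differs from compound 1 in one place: ethoxycarbonyl in place of hydrogen on an aromatic carbon. Within the data shown here, the only measured step, from compound 1 to compound 2, concerns the aromatic group attached to the triazole, not the thiazole ring where the new group enters, so it does not bear on this change. Among the measured compounds shown here, no measured pair tells how an ethoxycarbonyl group at this position affects the result in this assay. With nothing to guide a direction, compound 3 is expected to stay close to compound 1, giving no change at the digits printed from compound 1 to compound 3 (within the scatter), within the scatter. The estimated value for compound 3 is therefore 100 nM, with a range from 30 nM to 400 nM reflecting this uncertainty.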

Compound 3, half-maximal inhibitory concentration: 120 nM
Beside the measured number, compound 3's estimate is 1.2-fold (0.08 log units) below it; low and high end bracket the measured number.
By their numbers in this assay, from the lowest: compound 2; then compounds 1 and 3 (each within the scatter of the next).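

Putting ethoxycarbonyl in place of hydrogen on the aromatic carbon next to the ring sulfur gives, in this assay, a 1.2-fold higher number from compound 1 to compound 3 (0.08 log units; within the scatter), so this carbon carries a group of 5 heavy atoms with no difference that can be told from the scatter. Within the data shown here, the earlier step changed a different place, the aromatic group at the other end of the molecule, so this is the first reading of what this carbon tolerates. No available measurement speaks to why the number holds steady here.

On these data alone, whether a carboxylic acid or an amine on this same carbon would also leave the number in place remains open. As far as these compounds go, it is equally open whether ethoxycarbonyl would behave the same way in compound 2, which carries thiophen-2-yl instead of pyridin-4-yl.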